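The source may report more compounds than this note shows. Statements on the series, on what has been measured and on what is new or still open speak of the compounds shown alone.

Measured so far in a functional assay on BCG823 cells (Homo sapiens) for antiproliferative activity, read by MTT assay, with a stated time of 48 h; a lower number here means a stronger inhibitor, a higher number a weaker inhibitor:
compound 1 `COc1cc2oc(-c3ccccc3)cc(=O)c2c(O)c1OCCCCN1CCCC1` gives 10600 nM;
compound 2 `CCN(CC)CCCOc1c(OC)cc2oc(-c3ccccc3)cc(=O)c2c1O` gives 5700 nM;
compound 3 `O=c1cc(-c2ccccc2)oc2cc(O)c(OCCCCN3CCCCC3)c(O)c12` gives 52700 nM.

Compound 3 stands highest of the three, so it is the weakest inhibitor here. Compound 4 `COc1cc2oc(-c3ccccc3)cc(=O)c2c(O)c1OCCCCN1CCCCC1` differs from compound 3 in one place: methyl in place of hydrogen on an oxygen on an aromatic ring. Among the compounds with values here, no measured step turns on this same change. Within the data shown here, the only measured step, a 1.9-fold lower number from compound 1 to compound 2 (0.27 log units; within the scatter), alters the amine at the chain end and stays within the scatter. Compound 1 and compound 3 differ in two places at once, the amine ring and this oxygen, and their values sit apart beyond the scatter. Since the amine change looked small, compound 4 is expected to land near compound 1, an estimated step of a 4.4-fold lower number from compound 3 to compound 4 (0.64 log units; beyond the scatter). The estimate for compound 4 is 12000 nM, between 4000 nM and 36000 nM.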

Compound 4, half-maximal inhibitory concentration: 21900 nM
Compound 4: middle estimate off by 1.8-fold (0.26 log units), on the low side, and the stated range covers the measured number.
By their numbers in this assay, from the lowest: compounds 2 and 1 (each within the scatter of the next); then compound 4; then compound 3.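

Putting methyl in place of hydrogen on this oxygen on an aromatic ring, with the piperidine end kept the same, gives a modest gain in this assay (a 2.4-fold lower number from compound 3 to compound 4 (0.38 log units; beyond the scatter)), so hydroxy to methoxy now has a step of its own. The amine at the chain end also counts: both (a 2.1-fold higher number from compound 1 to compound 4 (0.32 log units; beyond the scatter)) and (a 3.8-fold higher number from compound 2 to compound 4 (0.58 log units; beyond the scatter)) lie beyond the scatter, unlike the earlier amine step. Nothing measured here explains either shift. From the compounds shown here alone, whether ethyl or a longer chain on this oxygen would lower the number further remains open, as does the effect of morpholine at the chain end.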